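Swapping the Phenyl Substituent, Expecting a Modest Shift

The compounds below may be only part of what the source reports. "The series", "measured", "known", "first", "only" and "open" are said of these compounds alone.

Of the compounds shown here, three built on one shared core have been measured in a functional assay on HepG2 cells (Homo sapiens) for inhibition, read by MTT assay, with a stated time of 72 h; on this read-out higher numbers stand for weaker inhibition and lower numbers for stronger inhibition. Compound 1 `CCc1cccc(-n2cc(COc3cccc(NC(=O)Nc4ccc(Cl)c(C(F)(F)F)c4)c3)nn2)c1` gives 37900 nM. Compound 2 `O=C(Nc1cccc(OCc2cn(-c3cccc(F)c3)nn2)c1)Nc1ccc(Cl)c(C(F)(F)F)c1` gives 2120 nM, and compound 3 `O=C(Nc1cccc(OCc2cn(-c3ccc(Br)cc3)nn2)c1)Nc1ccc(Cl)c(C(F)(F)F)c1` gives 2730 nM. Among these three, compound 2 carries the lowest number; its nearest neighbour is compound 3, and that gap lies within the scatter, so the two cannot be told apart, whereas the gap to compound 1 is far beyond it.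

Compound 4 `O=C(Nc1cccc(OCc2cn(-c3ccccc3C(F)(F)F)nn2)c1)Nc1ccc(Cl)c(C(F)(F)F)c1` has not yet been measured. It differs from compound 2 in a single place: 2-(trifluoromethyl)phenyl in place of 3-fluorophenyl on an aromatic nitrogen.

Going by the values given here, two measured steps bear on this change. Putting fluoro in place of ethyl on an aromatic carbon gave an 18-fold lower number from compound 1 to compound 2 (1.25 log units; beyond the scatter), a large move. Exchanging one halogen-bearing phenyl for another on the aromatic nitrogen gave a 1.3-fold higher number from compound 2 to compound 3 (0.11 log units; within the scatter). So the phenyl on the ring nitrogen can shift the number greatly or barely at all. Since the step from compound 2 to compound 4 also replaces fluoro with a fluorine-bearing group, only a small move toward a higher number is expected, a 1.9-fold higher number from compound 2 to compound 4 (0.28 log units; within the scatter), because a 1.3-fold higher number from compound 2 to compound 3 (0.11 log units; within the scatter) was small. For compound 4 in this assay the expected value is 4000 nM, within a range from 1500 nM to 15000 nM.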

Compound 4, half-maximal inhibitory concentration: 2320 nM
The estimate for compound 4 lay 1.7-fold (0.24 log units) above the measured number, within the range that was stated.
By their numbers in this assay, from the lowest: compounds 2, 4 and 3 (each within the scatter of the next); then compound 1.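

In this assay the exchange of 3-fluorophenyl for 2-(trifluoromethyl)phenyl on the aromatic nitrogen gives a 1.1-fold higher number from compound 2 to compound 4 (0.04 log units; within the scatter) and replaces a group with one that has more heavy atoms. Measured against the 4-bromophenyl group, the same substituent gives a 1.2-fold lower number from compound 3 to compound 4 (0.07 log units; within the scatter) and so also leaves the number within the scatter, which means that compounds 2, 3 and 4 cannot be told apart even though their phenyl groups carry different substituents at differently numbered ring positions. Compound 1 goes against this flat pattern, since its 3-ethylphenyl group stands well apart, with a 16-fold lower number from compound 1 to compound 4 (1.21 log units; beyond the scatter) and a large gap to the newly measured compound.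

These four compounds do not show whether the gap belongs to the ethyl group itself or to its place on the phenyl ring, and a 4-ethylphenyl, a propylphenyl, or a phenyl bearing an amine or a carboxylic acid could help separate those readings. The data at hand offer no independent measurement that explains why compound 1 stands apart from the other three.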